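A Second Chloro Group and Growth Inhibition in Colon Cells

The source may hold more compounds than are shown below. What is called first, only, known or untested is meant among the compounds shown, and "the series" means these compounds.

Compound 2 `ClCc1ccc(Cn2cnc3ncnc(Cl)c32)cc1` carries a chloromethyl group on its benzyl ring and a single chloro group on the shared core. In a functional assay on HCT-116 cells (Homo sapiens) for cytotoxicity, read by sulforhodamine B assay, with a stated time of 48 h (on this read-out higher numbers stand for weaker inhibition of growth and lower numbers for stronger inhibition of growth), compound 2 is recorded as "not determined" (no result reported), so it stands nowhere on the numbers shown. Two close relatives do have numbers: compound 1 `Nc1nc(Cl)c2ncn(Cc3cccc(CCl)c3)c2n1` gives 3890 nM in this assay, and compound 3 `ClCc1cccc(Cn2cnc3ncnc(Cl)c32)c1` gives 5240 nM. Compound 4 `ClCc1ccc(Cn2cnc3nc(Cl)nc(Cl)c32)cc1` differs from compound 2 by chloro in place of hydrogen on an aromatic carbon, placed on an aromatic carbon of a six-membered aromatic ring with 2 nitrogen. Without a measured step, no size or direction of change can be read from the data; a shift beyond the scatter is not expected. Compound 4 is estimated at 4500 nM, in a range from 1500 nM to 13000 nM.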

Compound 4, concentration for total growth inhibition: 1240 nM
The estimate for compound 4 lay 3.6-fold (0.56 log units) above the measured number; the measured number lies below the stated range.
By their numbers in this assay, from the lowest: compound 4; then compounds 1 and 3 (each within the scatter of the next).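

Compound 2 has no number, so no step from compound 2 to compound 4 can be read, and no measured evidence explains the result for compound 4. As far as these compounds go, whether adding the chloro group changes growth inhibition remains open.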